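The compounds below may be only part of what the source reports. "The series", "measured", "known", "first", "only" and "open" are said of these compounds alone.

Measured compounds:
compound 1 `Cc1cc(COc2ccccc2)nc(-c2ccccn2)n1`: 794 nM in a functional assay on cells for antagonist activity at Free fatty acid receptor 1 (Homo sapiens), read by TR-FRET and inositol phosphate accumulation, with a stated time of 2 h; a higher number here means a weaker inhibitor, a lower number a stronger inhibitor
compound 2 `COc1ccc(OCc2cc(C)nc(-c3ccccn3)n2)cc1`: 7940 nM in this assay

Compound 2 stands at the higher of the two numbers, giving the weaker inhibition; the step of a 10-fold higher number from compound 1 to compound 2 (1.00 log units; beyond the scatter) lies beyond the scatter and marks the only shown change on the phenoxy ring.

Compound 3 `Cc1cc(COc2ccc(C#N)cc2)nc(-c2ccccn2)n1` differs from compound 2 by cyano in place of methoxy on an aromatic carbon. For the measured compounds named here, the single measured step that bears on this position is a 10-fold higher number from compound 1 to compound 2 (1.00 log units; beyond the scatter), which shows that a methoxy placed para to the large group weakens inhibition relative to hydrogen. Going by the values given here, no measured step shows a cyano at any position, so the effect of exchanging methoxy for cyano is not established by the data; the expectation rests only on the observation that compound 2 is the weaker of the two and that a small acceptor at this site already costs activity.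

For compound 3 the number is expected to stay close to that of compound 2, with a step of a 1.6-fold lower number from compound 2 to compound 3 (0.20 log units; within the scatter) considered most likely. The estimate for compound 3 in this assay is 5000 nM, with a range from 1500 nM to 20000 nM.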

Compound 3, half-maximal inhibitory concentration: 31600 nM
Compound 3: the middle estimate sits 6.3-fold (0.80 log units) below what was measured; measured number outside the range, above it.
By their numbers in this assay, from the lowest: compound 1; then compound 2; then compound 3.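

At this position, on the six-membered aromatic ring of carbon only and para to a large group, the two substituents are not interchangeable in this assay: cyano in place of methoxy gives a 4.0-fold higher number from compound 2 to compound 3 (0.60 log units; beyond the scatter) even though both groups have the same computed counts of heavy atoms and hydrogen-bond acceptors. Cyano in place of hydrogen gives a 40-fold higher number from compound 1 to compound 3 (1.60 log units; beyond the scatter) and so adds to the loss seen with methoxy in a 10-fold higher number from compound 1 to compound 2 (1.00 log units; beyond the scatter), which leaves hydrogen with the lowest number of the three groups. No measurement here accounts for this order.

Still open, from the compounds shown here alone, is whether any substituent at this position can give a lower number than hydrogen, for example an amine, a hydroxyl or a carboxylic acid. Also open, going by these compounds, is whether methoxy and cyano keep the same order at other positions on this ring.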